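From Fluoro to Methoxy on One Aromatic Carbon

The source may hold more compounds than are shown below. What is called first, only, known or untested is meant among the compounds shown, and "the series" means these compounds.

In a functional assay on MKN-45 cells (Homo sapiens) for inhibition, with a stated time of 72 h (a lower number here means a stronger inhibitor, a higher number a weaker inhibitor), compound 1 `COc1ccc(S(=O)(=O)N2CCc3cccc(-c4ccc(N(C)C)cc4)c32)cc1` gives 237 nM, while compound 2 `COc1ccc(S(=O)(=O)N2CCc3cccc(-c4ccc(F)cc4)c32)cc1` gives 79 nM, the lower of the two numbers. Compound 3 `COc1ccc(-c2cccc3c2N(S(=O)(=O)c2ccc(OC)cc2)CC3)cc1` differs from compound 2 by methoxy in place of fluoro on an aromatic carbon, with methoxy in place of fluoro on an aromatic carbon, para to a large group. Among the measured compounds shown here, only one measured step bears on this change: a 3.0-fold lower number from compound 1 to compound 2 (0.48 log units; beyond the scatter), so a modest change or a smaller one is expected, with its direction open. The estimated change is a 1.1-fold lower number from compound 2 to compound 3 (0.05 log units; within the scatter). For compound 3, the expected value is 70 nM, with an estimated range from 22 nM to 220 nM.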

Compound 3, half-maximal inhibitory concentration: 211 nM
Compound 3: the middle estimate sits 3.0-fold (0.48 log units) below what was measured; measured number inside the range.
By their numbers in this assay, from the lowest: compound 2; then compounds 3 and 1 (each within the scatter of the next).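

In this assay the change from 4-fluorophenyl to 4-methoxyphenyl gives a 2.7-fold higher number from compound 2 to compound 3 (0.43 log units; beyond the scatter) and so moves the number back up at this position, para to a large group. Methoxy and dimethylamino are not told apart here, with a 1.1-fold lower number from compound 1 to compound 3 (0.05 log units; within the scatter) lying within the scatter, which leaves fluoro alone with the lowest number of the three. No measured evidence accounts for this difference.

From the compounds shown here alone, what stays open is where a chloro, an amine or a carboxylic acid on this aromatic carbon would fall. The compounds shown also leave open whether fluoro's lead would hold on another core.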